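A few compounds are considered here, and "the series" means these few. Any claim that something is new, unique, unknown or untested is made for them only; others in the source may bear on it.

Measured so far in a functional assay on HEK293 cells for agonist activity at G-protein coupled receptor 39 (Homo sapiens), read by scintillation proximity assay and inositol phosphate accumulation, with a stated time of 75 min; on this read-out lower numbers stand for an effect already at smaller amounts and higher numbers for an effect only at larger amounts of compound:
compound 1, `Cc1nn(-c2ncnc3nc[nH]c23)c2c1C(OCC(=O)c1ccc(F)cc1)CC(=O)N2` — 973 nM
compound 2, `Cc1nn(-c2ncnc3nc[nH]c23)c2c1C(NC(=O)c1ccccc1)CC(=O)N2` — 158 nM

Compound 2 holds the lowest of the two numbers; compound 1 sits beyond the scatter above it. Among the measured compounds shown here, no pair differing in a single place is measured, so no step size is established.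

Compound 3, `Cc1nn(-c2ncnc3nc[nH]c23)c2c1C(OCCn1nccc1C)CC(=O)N2`, is not yet measured. Its difference from compound 2: a group of 9 heavy atoms (6 carbon, 2 nitrogen, 1 oxygen; one five-membered aromatic ring with 2 hetero atoms) in place of a group of 9 heavy atoms (7 carbon, 1 nitrogen, 1 oxygen; one six-membered aromatic ring of carbon only), on a saturated ring carbon. The benzamido group, with its 1 hydrogen-bond donor, is exchanged for a group with 0 hydrogen-bond donors and 3 hydrogen-bond acceptors.

Compound 3 is expected to give a higher number than compound 2 in this assay, a step of a 3.2-fold higher number from compound 2 to compound 3 (0.50 log units; beyond the scatter), because compound 1, which likewise carries 0 hydrogen-bond donors at that saturated ring carbon, gives 973 nM. The estimate for compound 3 is 500 nM, within 150 nM to 1600 nM.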

Compound 3, half-maximal effective concentration: 1620 nM
Estimate against measurement, compound 3: 3.2-fold (0.51 log units) below, and the stated range ends below it.
By their numbers in this assay, from the lowest: compound 2; then compounds 1 and 3 (each within the scatter of the next).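

In this assay the saturated ring carbon, three ring bonds from the ring nitrogen, now has a measured sensitivity: the group with the five-membered aromatic ring in place of benzamido gives a 10-fold higher number from compound 2 to compound 3 (1.01 log units; beyond the scatter) in one change. The two groups with 0 hydrogen-bond donors are not separated, with (5-methyl-1H-pyrazol-1-yl)methyl in place of (4-fluorophenyl)carbonyl giving a 1.7-fold higher number from compound 1 to compound 3 (0.22 log units; within the scatter) on the chain, so of these three compounds only compound 2, the benzamido compound, stands apart. No measurement here bears on the reason for the large step.

From the compounds shown here alone, whether the amide hydrogen of benzamido matters remains open, and a methylated amide on that saturated ring carbon would test it. Going by these compounds, how an amine or a carboxylic acid would read at the same carbon also remains open.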